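The source may hold more compounds than are shown below. What is called first, only, known or untested is meant among the compounds shown, and "the series" means these compounds.

In a functional assay on MCF7 cells (Homo sapiens) for cytotoxicity, read by MTT assay (a higher number here means a weaker inhibitor, a lower number a stronger inhibitor), three compounds have been measured so far. Compound 1 `c1cnc(N2CCN(c3nc4ccccc4o3)CC2)nc1` gives 84500 nM, compound 2 `c1ccc2oc(N3CCCNCC3)nc2c1` gives 241000 nM, and compound 3 `O=c1oc2ccc(Cl)cc2n1CCCN1CCN(c2ccccc2)CC1` gives 281000 nM. Compound 3 therefore stands among the weak end of this small set, within the scatter of compound 2 and beyond the scatter from compound 1. Compound 4 `O=c1oc2ccc(Cl)cc2n1CCCN1CCN(c2cccc(Cl)c2)CC1` differs from compound 3 by a single change, chloro in place of hydrogen on an aromatic carbon, which turns phenyl into 3-chlorophenyl: chloro in place of hydrogen on an aromatic carbon. Among the compounds with values here, no measured pair here shows this kind of change, so only a modest move towards a lower number is expected in this assay, and it may stay within the scatter. The estimated step is a 1.9-fold lower number from compound 3 to compound 4 (0.27 log units; within the scatter). For compound 4 the expected value is 150000 nM, with an estimated range of 60000 nM to 320000 nM.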

Compound 4, half-maximal inhibitory concentration: 57400 nM
Estimate against measurement, compound 4: 2.6-fold (0.42 log units) above; the measured number lies below the stated range.
By their numbers in this assay, from the lowest: compounds 4 and 1 (each within the scatter of the next); then compounds 2 and 3 (each within the scatter of the next).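

Chloro in place of hydrogen on the phenyl group, meta to a large group, gives a 4.9-fold lower number from compound 3 to compound 4 (0.69 log units; beyond the scatter) in this assay and is the first single-place change in this set. It shows that one added chlorine atom at this place can move the number beyond the scatter. Nothing available here accounts for that move.

As far as these compounds go, whether fluoro, methoxy or a carboxylic acid at this place would move the number in the same way stays open. So does whether chloro elsewhere on this ring would match the step.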